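A few compounds are considered here, and "the series" means these few. Any claim that something is new, unique, unknown or untested is made for them only; others in the source may bear on it.

In a functional assay on HCT-116 cells (Homo sapiens) for cytotoxicity (a lower number here means a stronger inhibitor, a higher number a weaker inhibitor), compound 1 `COc1cc(N2CCN(C(=O)N3CCN(C)CC3)CC2)ccc1Nc1nc(NC2CCCCC2)c2nc[nH]c2n1` gives 17 nM, compound 2 `COc1cc(N2CCN(Cc3ccccn3)CC2)ccc1Nc1nc(NC2CCCCC2)c2nc[nH]c2n1` gives 51 nM, and compound 3 `COc1cc(N2CCC(C(=O)N3CCC(N(C)C)C3)CC2)ccc1Nc1nc(NC2CCCCC2)c2nc[nH]c2n1` gives 58 nM. Compound 3 and compound 2 therefore lie within the usual scatter of each other, and the numbers of both sit clearly higher than that of compound 1.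

The next compound to be tested is compound 4 `COc1cc(N2CCC(CC(=O)N3CCOCC3)CC2)ccc1Nc1nc(NC2CCCCC2)c2nc[nH]c2n1`. It differs from compound 3 on a saturated ring carbon of a six-membered non-aromatic ring with 1 nitrogen, where ((morpholin-4-yl)carbonyl)methyl stands in place of (3-(dimethylamino)pyrrolidin-1-yl)carbonyl: ((morpholin-4-yl)carbonyl)methyl in place of (3-(dimethylamino)pyrrolidin-1-yl)carbonyl on a saturated ring carbon.

Going by the values given here, no measured pair makes this exact exchange, so the evidence is indirect. Among the compounds with values here, the only measured step is a 3.0-fold higher number from compound 1 to compound 2 (0.48 log units; beyond the scatter). It swaps a different pair of groups, on an amine nitrogen in a ring rather than on a ring carbon, and it is modest. It suggests that large groups in this part of these compounds can shift the number, but not dramatically. With nothing to fix a direction, no shift beyond the scatter is expected in this assay. The expected step is a 1.4-fold higher number from compound 3 to compound 4 (0.14 log units; within the scatter). For compound 4 the estimated value is 80 nM, with an expected range from 25 nM to 250 nM.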

Compound 4, half-maximal inhibitory concentration: 36 nM
The estimate for compound 4 lay 2.2-fold (0.35 log units) above the measured number; measured number inside the range.
By their numbers in this assay, from the lowest: compound 1; then compounds 4, 2 and 3 (each within the scatter of the next).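

Going by these compounds alone, this is the first measured change on the saturated ring carbon of the six-membered ring with 1 nitrogen, and in this assay it amounts to a 1.6-fold lower number from compound 3 to compound 4 (0.21 log units; within the scatter), so this replacement leaves the number within the usual scatter. The exchange is not a small one: (3-(dimethylamino)pyrrolidin-1-yl)carbonyl, with 10 heavy atoms including 2 nitrogens and a five-membered ring, gives way to ((morpholin-4-yl)carbonyl)methyl, with 9 heavy atoms including 1 nitrogen and 2 oxygens and a six-membered ring, while the count of hydrogen-bond acceptors stays the same. At this position, then, the dimethylamino group and the pyrrolidine ring of compound 3 can be exchanged for the morpholine and its methyl link with no readable change in this cell assay, and nothing measured here explains why.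

Going by these compounds, compound 3 and compound 4 differ in the ring and in the methyl link at once, so the contribution of each part remains unknown. On these data alone, it also remains open whether a much smaller or differently charged group on this ring carbon, such as a hydroxyl, a primary amine or a carboxylic acid, would move the number beyond the scatter.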